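Chloro on the methyl-bearing core: compound 3 to compound 4

The source may report more compounds than this note shows. Statements on the series, on what has been measured and on what is new or still open speak of the compounds shown alone.

Three compounds share one core and are compared in an assay on isolated protein for inhibition of Nicotinamide N-methyltransferase (Homo sapiens), read by luminescence, with a stated time of 20 min; a higher number here means a weaker inhibitor, a lower number a stronger inhibitor. Compound 1 `C[C@H]1Cc2cc(C(N)=O)cnc2N1` gives only a limit, > 10000 nM, in this assay. Compound 3 `C[C@@H]1Cc2cc(C(N)=O)cnc2N1` is its counterpart with the other drawn configuration; in this assay compound 3 gives 42 nM; the step of an at least 230-fold lower number from compound 1 to compound 3 (2.37 log units; beyond the scatter) rests on nothing more than the fact that compounds 1 and 3 differ only in the configuration as drawn. Compound 2 `NC(=O)c1cnc2c(c1Cl)CCN2`, which carries chloro but no methyl, gives 92 nM. Compound 3 therefore stands at the lowest number shown, with compound 2 next and compound 1 a limit.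

Compound 4 `C[C@@H]1Cc2c(ncc(C(N)=O)c2Cl)N1` is compound 3 with chloro in place of hydrogen on an aromatic carbon, on an aromatic carbon of a six-membered aromatic ring with 1 nitrogen, part of a fused system of two rings, ortho to a carbamoyl group, ortho to a fused ring, meta to a fused ring and opposite the ring nitrogen. Going by the values given here, no measured step follows this change in one place; the only measured step, an at least 230-fold lower number from compound 1 to compound 3 (2.37 log units; beyond the scatter), concerns configuration alone. Among the compounds with values here, compound 2 and compound 3 differ in two places and show only that the chloro-bearing core without methyl sits somewhat higher. The step of a 1.1-fold lower number from compound 3 to compound 4 (0.02 log units; within the scatter) is therefore expected to stay within the scatter. Compound 4 is estimated at 40 nM, between 12 nM and 150 nM, in this assay.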

Compound 4, half-maximal inhibitory concentration: 48 nM
Compound 4: middle estimate off by 1.2-fold (0.08 log units), on the low side, and the stated range covers the measured number.
By their numbers in this assay, from the lowest: compounds 3, 4 and 2 (each within the scatter of the next, the first and the last beyond it). At a limit, above all of these: compound 1.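

Chloro in place of hydrogen on this aromatic carbon, ortho to a carbamoyl group and opposite the ring nitrogen, is tolerated on the methyl-bearing core in this assay: the step is a 1.1-fold higher number from compound 3 to compound 4 (0.06 log units; within the scatter), so the number does not move beyond the scatter with this change. The methyl, read on the chloro-bearing core, gives the same kind of result: methyl in place of hydrogen on a saturated ring carbon, in the configuration drawn for compound 3, gives a 1.9-fold lower number from compound 2 to compound 4 (0.28 log units; within the scatter), so neither single change in this small set separates its pair. Nothing on hand bears on why either step stays this small.

Open, on these data alone, is whether bromo, methoxy or an amine on this aromatic carbon would also stay within the scatter of compound 3, and whether a longer chain such as ethyl in place of the methyl on the saturated ring carbon would stay within the scatter of compound 4. Also open, as far as these compounds go, is whether chloro on this aromatic carbon would alter the picture for compound 1, whose > 10000 nM is a limit of the assay and not a number.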